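This account rests on a few compounds, and the source may have more. Where it says the series, first, only, none or still open, it means among the compounds named here.

Measured in an ADME assay (liver, Mus musculus) for metabolic stability, read by LC-MS, using microsomes and NADPH, with a stated time of 1 h, tested at 1 uM (a lower number here means that less of the compound is left, a higher number that more of the compound is left), so far
Compound 1 `O=C(O)c1cnc(Oc2ccc3c(c2)B(O)OC3)cn1` gives "not determined" (no result reported)
Compound 2 `COC(=O)c1cnc(Oc2ccc3c(c2)B(O)OC3)cn1` gives 0%

Going by the values given here, compound 2 holds the only number in this assay, and with 0% as its value compound 2 stands at the bottom of the read-out. Compound 1 offers no number for comparison. Compound 3 `NC(=O)c1cnc(Oc2ccc3c(c2)B(O)OC3)cn1` keeps the shared core but carries amino in place of methoxy on a carbonyl carbon, so methoxycarbonyl becomes carbamoyl. Among the compounds with values here, no measured step gives a guide to size, but from the 0% of compound 2 any real change can only go upward. The expected rise a number 65 percentage points higher from compound 2 to compound 3 (beyond the scatter) is large, well beyond the usual scatter. In this assay the expected value for compound 3 is 65% in a range from 30% to 95% as estimated here.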

Compound 3, percent of the compound remaining: 97%
For compound 3 the middle estimate is 32 percentage points below the measured one; the whole stated range lies below it.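

In this assay, the group on the carbonyl carbon turns out to decide the read-out: amino in place of methoxy, which makes methoxycarbonyl into carbamoyl, gives a number 97 percentage points higher from compound 2 to compound 3 (beyond the scatter). The shared core is the same in both compounds, so the core alone does not fix how much compound is left. Nothing shown here accounts for this step. Going by these compounds, it remains open whether a methylamino or dimethylamino group on the same carbonyl carbon would behave like amino, and whether an ethoxy group would behave like methoxy.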